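The source may hold more compounds than are shown below. What is called first, only, known or untested is meant among the compounds shown, and "the series" means these compounds.

In an assay for inhibition of Amine oxidase [flavin-containing] A (Bos taurus), read by fluorescence, with a stated time of 30 min (a higher number here means a weaker inhibitor, a lower number a stronger inhibitor), compound 2 `Cc1c(C)c2ccc(OCC(=O)NN)cc2oc1=O` gives 0.00501 nM and holds the lowest number of the three measured: compound 3 `Cc1c(C)c2ccc(OCc3nnc(S)s3)cc2oc1=O` gives 0.00637 nM, a gap within the scatter, while compound 1 `Cc1cc(=O)oc2cc(OCC(=O)NN)ccc12` gives 0.0112 nM, the step of a 2.2-fold lower number from compound 1 to compound 2 (0.35 log units; beyond the scatter) lying beyond it. Compound 4 `Cc1c(C)c2ccc(OCC(=O)N/N=C/c3ccc(Cl)cc3)cc2oc1=O` differs from compound 2 by a group of 9 heavy atoms (7 carbon, 1 nitrogen, 1 chlorine; one six-membered aromatic ring of carbon only) in place of one nitrogen atom, on an amide-type nitrogen. Among the measured compounds shown here, only the step of a 1.3-fold higher number from compound 2 to compound 3 (0.10 log units; within the scatter) touches that same end of the molecule, and it stayed within the scatter; the methyl step from compound 1 to compound 2 says nothing about this position. The change in compound 4 is therefore expected to bring no step beyond the scatter in this assay, the step of a 1.2-fold higher number from compound 2 to compound 4 (0.08 log units; within the scatter) being an estimate. Compound 4 is expected to give about 0.006 nM, between 0.002 nM and 0.02 nM.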

Compound 4, inhibition constant: 0.00554 nM
Estimate against measurement, compound 4: 1.1-fold (0.03 log units) above, within the range that was stated.
By their numbers in this assay, from the lowest: compounds 2, 4, 3 and 1 (each within the scatter of the next, the first and the last beyond it).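

In this assay, replacing the amino group on the amide-type nitrogen with the much larger chlorine-bearing aromatic group gives a 1.1-fold higher number from compound 2 to compound 4 (0.04 log units; within the scatter). The earlier compounds shown here left this nitrogen unexplored, and this pair shows that it can carry a group of 9 heavy atoms, including a six-membered aromatic ring and a double bond outside it, with no step beyond the scatter. No available evidence explains this result. From the compounds shown here alone, it remains open whether the chlorine or the aromatic ring contributes anything here, as a hydrogen or methoxy group in place of the chlorine, or a cyclohexyl group in place of the ring, would test. A saturated amine linkage in place of the double bond is equally untested among these compounds.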